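The compounds below may be only part of what the source reports. "The series", "measured", "known", "first", "only" and "open" are said of these compounds alone.

Compound 1, `CN1CCN(c2ccc(C3=NN(C(=O)/C=C/c4ccccc4)C(c4ccc(N(C)C)cc4)C3)cc2)CC1`, in a functional assay on A549 cells (Homo sapiens) for inhibition (a lower number here means a stronger inhibitor, a higher number a weaker inhibitor), gives > 10000 nM, which is a limit of the assay. Compound 2, `CN1CCN(c2ccc(C3=NN(S(=O)(=O)c4ccc(F)cc4)C(c4ccc(N(C)C)cc4)C3)cc2)CC1`, in this assay gives 9600 nM. Compound 3, `CN1CCN(c2ccc(C3=NN(S(=O)(=O)c4ccc(Br)cc4)C(c4ccc(N(C)C)cc4)C3)cc2)CC1`, in this assay gives > 10000 nM, again a limit of the assay.

Compound 3 therefore stands at the edge of what this assay can read: its value is a limit rather than a number, and the limit of > 10000 nM in this assay, at which 2 of the 3 values shown sit, shows that this is the usual outcome among these three compounds. Compound 4, `CN1CCN(c2ccc(C3=NN(S(=O)(=O)c4ccc(C#N)cc4)C(c4ccc(N(C)C)cc4)C3)cc2)CC1`, differs from compound 3 by a single change, (cyano in place of bromo on an aromatic carbon). The measured steps that bear on it are few. The closest is the earlier swap of one group for another at the same position on the shared core, an at least 1.0-fold higher number from compound 2 to compound 3 (0.01 log units; that floor lies within the scatter), which stays within the scatter. The step that the two limits leave unreadable from compound 1 to compound 3 cannot be sized, and an at least 1.0-fold lower number from compound 1 to compound 2 (0.01 log units; that floor lies within the scatter) is likewise within the scatter. Since all three values gather near the limit, no step beyond the scatter is expected for compound 4: the expected step is a number no higher from compound 3 to compound 4 (the limit leaves the size open). Compound 4 is estimated at 10000 nM, with a range from 4000 nM to 30000 nM, and a real chance that only a limit is reported.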

Compound 4, half-maximal inhibitory concentration: 3600 nM
For compound 4 the middle estimate is 2.8-fold (0.44 log units) above the measured one, and the stated range ends above it.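

Cyano in place of bromo gives an at least 2.7-fold lower number from compound 3 to compound 4 (0.44 log units; beyond the scatter), and cyano in place of fluoro gives a 2.7-fold lower number from compound 2 to compound 4 (0.43 log units; beyond the scatter), which shows that a change on this aromatic carbon can move the number beyond the scatter, something the swap of fluoro for bromo could not show. The (4-cyanophenyl)sulfonyl group in place of (2-phenylethenyl)carbonyl gives an at least 2.7-fold lower number from compound 1 to compound 4 (0.44 log units; beyond the scatter), yet the sulfonyl group alone does not account for this step, as compound 2 and compound 3 carry it without a readable gain over compound 1. From the compounds shown here alone, compound 3 gives > 10000 nM, which is a limit, so the true size of the step to cyano stays open, and limits remain common in this small set: the limit of > 10000 nM in this assay, at which 2 of the 4 values shown sit.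

Going by these compounds, whether a nitro group, an amine or a carboxylic acid on this same aromatic carbon would lower the number further remains open. With only fluoro, bromo and cyano shown here, the compounds also cannot tell what it is about cyano that goes with the lower number.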